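Moving a Ring Nitrogen Within a Weak Urea Series

The compounds below may be only part of what the source reports. "The series", "measured", "known", "first", "only" and "open" are said of these compounds alone.

Compound 3 `O=C(Nc1ccc(-n2ncc3ccncc32)cc1)Nc1ccc(Cl)c(C(F)(F)F)c1` stands at the edge of what is known. In a functional assay on SGC-7901 cells (Homo sapiens) for cytotoxicity, read by MTT assay, with a stated time of 72 h (a lower number here means a stronger inhibitor, a higher number a weaker inhibitor), compound 3 gives > 32000 nM, which is a limit of the assay rather than a number. Compound 1 `O=C(Nc1ccc(-n2ncc3c(Cl)cccc32)cc1)Nc1ccc(Cl)c(C(F)(F)F)c1` gives 4600 nM in this assay, and compound 2 `O=C(Nc1ccc(-n2ncc3c(Br)cccc32)cc1)Nc1ccc(Cl)c(C(F)(F)F)c1` gives 16600 nM in this assay. Compound 4 `O=C(Nc1ccc(-n2ncc3cccnc32)cc1)Nc1ccc(Cl)c(C(F)(F)F)c1` differs from compound 3 by a group of 9 heavy atoms (6 carbon, 3 nitrogen; one five-membered aromatic ring with 2 hetero atoms, one six-membered aromatic ring with 1 hetero atom) in place of a group of 9 heavy atoms (6 carbon, 3 nitrogen; one five-membered aromatic ring with 2 hetero atoms, one six-membered aromatic ring with 1 hetero atom), on an aromatic carbon. For the measured compounds named here, the measured steps of an at least 6.9-fold higher number from compound 1 to compound 3 (0.84 log units; beyond the scatter) and an at least 1.9-fold higher number from compound 2 to compound 3 (0.28 log units; that floor lies within the scatter) both concern replacing a six-membered aromatic ring of carbon only with a six-membered aromatic ring with 1 hetero atom, not moving that hetero atom, so they set no direction for this step, and no change beyond the scatter is expected. Compound 4 is therefore estimated at 40000 nM in this assay, within a range from 12000 nM to 130000 nM. This amounts to an expected step that the limit leaves unreadable from compound 3 to compound 4.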

Compound 4, half-maximal inhibitory concentration: > 32000 nM
Compound 4 gave a limit, no number; the forecaster's own chance of this, stated with the estimate: 60%; the middle value does not contradict the limit.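

In this assay compound 4 gives > 32000 nM as a limit of the assay and not a number. Moving the ring nitrogen keeps the series weak, with an at least 6.9-fold higher number from compound 1 to compound 4 (0.84 log units; beyond the scatter) and, with a floor that stays inside the scatter, an at least 1.9-fold higher number from compound 2 to compound 4 (0.28 log units; that floor lies within the scatter) and no more can be said of that second step. The step between the two nitrogen placings cannot be read, because both compounds stop at the same limit: the limit of > 32000 nM in this assay, at which 2 of the 4 values shown sit.

Which nitrogen placing is the better one stays open. So does what an amine or a methoxy group in place of chloro on the core would give.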